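Swapping an Ether Tail: An Estimate for Compound 4

The source may hold more compounds than are shown below. What is called first, only, known or untested is meant among the compounds shown, and "the series" means these compounds.

Compound 1 `C=CC(=O)Nc1cccc(Nc2nc(Cl)nc(Nc3ccc(OCCOC)cc3)n2)c1`: "not determined" (no result reported)
Compound 2 `C=CC(=O)N1CCc2ccc(Nc3ncnc(Nc4ccc(C(=O)N5CCCCC5)cc4)n3)cc21`: "not determined" (no result reported)
Compound 3 `C=CC(=O)Nc1cccc(Nc2ncnc(Nc3ccc(-c4ccc(Cl)nc4)cc3)n2)c1`: 160000 nM

In a functional assay on Ramos cells (Homo sapiens) for antiproliferative activity, read by CCK-8 assay, with a stated time of 24 h (a higher number here means a weaker inhibitor, a lower number a stronger inhibitor), compound 1 gives "not determined" (no result reported), so it stands without a number; compound 2 likewise gives "not determined" (no result reported). Only compound 3 carries a result, 160000 nM, a weak one. Compound 4 `C=CC(=O)Nc1cccc(Nc2nc(Cl)nc(Nc3ccc(Oc4ccccc4)cc3)n2)c1` departs from compound 1 in a single spot: phenyl in place of 2-methoxyethyl on an oxygen on an aromatic ring. For the measured compounds named here, with no number for compound 1, no step can be computed, and the account expects the change to move the result in this assay by no more than the usual scatter in either direction. Resting on compound 3 and its 160000 nM as the only anchor, the result for compound 4 is estimated at 80000 nM, within 20000 nM to 300000 nM.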

Compound 4, half-maximal inhibitory concentration: 12300 nM
Beside the measured number, compound 4's estimate is 6.5-fold (0.81 log units) above it; measured number below the stated range.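

In this assay, for the compounds shown here, compound 1 gives "not determined" (no result reported), so no step to compound 4 can be read. Going by these compounds, the effect of going from 2-methoxyethoxy to phenoxy stays open, and no evidence here bears on the result.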